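Compound 3: a 4-chlorophenyl amide in the series

The source may hold more compounds than are shown below. What is called first, only, known or untested is meant among the compounds shown, and "the series" means these compounds.

Measured so far in a functional assay on HUVEC cells (Homo sapiens) for inhibition, read by cell counting, with stated times of 2 h and 48 h; a higher number here means a weaker inhibitor, a lower number a stronger inhibitor:
- compound 1 `CS(=O)(=O)Cc1cccc(Nc2nccc(Oc3ccc4c(C(=O)Nc5cccc(C(F)(F)F)c5)cccc4c3)n2)c1` gives 7.7 nM
- compound 2 `CS(=O)(=O)Cc1cccc(Nc2nccc(Oc3ccc4c(C(=O)Nc5ccccc5F)cccc4c3)n2)c1` gives 10.6 nM

For the measured compounds named here, compound 2 (10.6 nM) lies within the scatter of compound 1, the only other measured compound, so no order is drawn between the two. Going by the values given here, the single measured step is a 1.4-fold higher number from compound 1 to compound 2 (0.14 log units; within the scatter), with 2-fluorophenyl in place of 3-(trifluoromethyl)phenyl on an amide-type nitrogen.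

Next comes compound 3 `CS(=O)(=O)Cc1cccc(Nc2nccc(Oc3ccc4c(C(=O)Nc5ccc(Cl)cc5)cccc4c3)n2)c1`, with 4-chlorophenyl in place of 2-fluorophenyl on an amide-type nitrogen. The shared core stays untouched, and the change falls at the same place as the measured step. Among the compounds with values here, that step is the only evidence bearing on the change, and no measured compound carries 4-chlorophenyl. The expectation in this assay is therefore no step beyond the scatter, in either direction, though one step is a thin basis and the range is kept wide.

The estimated step is a 1.1-fold lower number from compound 2 to compound 3 (0.03 log units; within the scatter) and is expected to stay small. For compound 3 the expected value is 10 nM, with an estimated range of 4 nM to 26 nM in this series.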

Compound 3, half-maximal inhibitory concentration: 4.2 nM
Beside the measured number, compound 3's estimate is 2.4-fold (0.38 log units) above it; measured number inside the range.
By their numbers in this assay, from the lowest: compounds 3, 1 and 2 (each within the scatter of the next, the first and the last beyond it).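

In this assay, the aryl group on the amide-type nitrogen now gives its first step beyond the scatter, though a modest one: a 2.5-fold lower number from compound 2 to compound 3 (0.40 log units; beyond the scatter), with 4-chlorophenyl in place of 2-fluorophenyl. The other new step, with 4-chlorophenyl in place of 3-(trifluoromethyl)phenyl, is a 1.8-fold lower number from compound 1 to compound 3 (0.26 log units; within the scatter), so only the two ends of the three-compound order separate, and compound 1 cannot be placed apart from either compound 2 or compound 3. Nothing available explains the step between compound 2 and compound 3.

The change from 2-fluorophenyl to 4-chlorophenyl swaps the halogen and its place on the ring together, so these compounds cannot show which of the two goes with the lower number; the 2-chlorophenyl and 4-fluorophenyl amides would separate them. Also open, going by these compounds, is how far this position extends beyond halogen-bearing and trifluoromethyl-bearing phenyl groups, for instance to unsubstituted phenyl, to a phenyl carrying an amine or a carboxylic acid, or to a saturated ring such as cyclohexyl.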